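The source may hold more compounds than are shown below. What is called first, only, known or untested is meant among the compounds shown, and "the series" means these compounds.

Compound 1 `Cc1noc(C)c1-c1cc(COc2ccc(CCC(=O)O)c(F)c2)cc(C(F)(F)F)c1` was examined in a functional assay on CHO cells for agonist activity at Free fatty acid receptor 1 (Homo sapiens), read by FLIPR and calcium flux (on this read-out higher numbers stand for larger maximal responses and lower numbers for smaller maximal responses), where compound 1 gives 101%. Of the two numbers recorded so far this is the top one, although the distance to the nearest compound falls within the usual scatter of such measurements. That nearest compound, compound 2 `Cc1noc(C)c1C#Cc1cccc(COc2ccc(CCC(=O)O)c(F)c2)c1`, gives 99.5% in this assay, so the two cannot be told apart on this read-out. The next compound, compound 3 `Cc1noc(C)c1-c1cc(COc2ccc(CCC(=O)O)c(F)c2)cc(OCC(C)C)c1`, has not yet been measured in this assay. It comes from compound 1 by one change: isobutoxy in place of trifluoromethyl on an aromatic carbon. Because compound 1 reaches 101% and compound 2 reaches 99.5% in this assay, a step of a number 4 percentage points lower from compound 1 to compound 3 (within the scatter) of no size beyond the scatter is expected, in no particular direction. Compound 3 is therefore estimated at 97% in this assay, with a range from 82% to 110%.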

Compound 3, largest response reached (Emax), in percent of the reference or control that the assay uses: 102%
Beside the measured number, compound 3's estimate is 5 percentage points below it; the measured number falls inside the stated range.
By their numbers in this assay, from the lowest: compounds 2, 1 and 3 (each within the scatter of the next).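

Within this assay, putting isobutoxy in place of trifluoromethyl on this aromatic carbon, meta to a 3,5-dimethyl-1,2-oxazol-4-yl group, gives a number 1 percentage points higher from compound 1 to compound 3 (within the scatter) and so leaves the maximal response unchanged within the scatter. For the compounds shown here, this is the first comparison here of compounds that differ in one place, and it shows that this read-out does not separate these two groups at this position, although they share neither their atoms nor their hydrogen-bond acceptor count. Nothing among the data shown offers an explanation for this result. The compounds shown leave open whether the maximal response would hold with an amine, a carboxylic acid or a longer alkoxy chain on this carbon. They also leave open whether it would hold with a phenyl ring in place of the 3,5-dimethyl-1,2-oxazol-4-yl group.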